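Furan-2-yl ketone in the enone series: expected potency

The source may report more compounds than this note shows. Statements on the series, on what has been measured and on what is new or still open speak of the compounds shown alone.

Measured compounds in a functional assay on MDA-MB-231 cells (Homo sapiens) for antiproliferative activity, read by XTT assay, with a stated time of 72 h; on this read-out lower numbers stand for stronger inhibition and higher numbers for weaker inhibition:
- compound 1 `COc1ccc(-c2cc3ccccc3nc2C=O)cc1`: gives only a limit of the assay, > 10000 nM
- compound 2 `COc1ccc(-c2cc3ccccc3nc2/C=C/C(=O)c2ccccc2)cc1`: 860 nM
- compound 3 `COc1ccc(-c2cc3ccccc3nc2/C=C/C(=O)c2ccc(N)cc2)cc1`: 7510 nM

Compound 3 holds the highest of the two numbers that are not limits; its nearest neighbour is compound 2, and the step of an 8.7-fold higher number from compound 2 to compound 3 (0.94 log units; beyond the scatter) separates them. For compound 1 the read-out is a limit only, as noted in the limit of > 10000 nM in this assay, at which 1 of the 3 values shown sits.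

The unmeasured compound 4 `COc1ccc(-c2cc3ccccc3nc2/C=C/C(=O)c2ccco2)cc1` differs from compound 3 on the carbonyl carbon whose other neighbour is the double-bonded chain carbon: furan-2-yl in place of 4-aminophenyl on a carbonyl carbon. Within the data shown here, the only measured step at this position is an 8.7-fold higher number from compound 2 to compound 3 (0.94 log units; beyond the scatter), which shows that bringing the amino group onto the aromatic ring in compound 3 raised the number well beyond the scatter. Compound 4 removes that amino group and the whole six-membered aromatic ring along with it, putting a smaller five-membered aromatic ring in its place. Among the measured compounds shown here, no measured pair shows a phenyl-to-furan exchange, so the size of that part of the change is not known from this series.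

The expectation is therefore a lower number than compound 3, of roughly the size seen between compound 3 and compound 2, stated as a 5.0-fold lower number from compound 3 to compound 4 (0.70 log units; beyond the scatter). Compound 4 is estimated at 1500 nM in this assay, with a range from 400 nM to 6000 nM.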

Compound 4, half-maximal inhibitory concentration: 630 nM
For compound 4 the middle estimate is 2.4-fold (0.38 log units) above the measured one; the range from low to high includes it.
By their numbers in this assay, from the lowest: compounds 4 and 2 (each within the scatter of the next); then compound 3. At a limit, above all of these: compound 1.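

In this assay the exchange of phenyl for furan-2-yl on the carbonyl carbon gives a 1.4-fold lower number from compound 2 to compound 4 (0.14 log units; within the scatter) and so shows that this position takes a five-membered aromatic ring with one hetero atom without a readable change. Set against the 4-aminophenyl ketone, the same ring gives a 12-fold lower number from compound 3 to compound 4 (1.08 log units; beyond the scatter) and leaves compound 3 as the one enone shown that stands apart from the other two, while compounds 2 and 4 cannot be ordered. The full 2-((furan-2-yl)carbonyl)ethenyl group in place of formyl gives an at least 15-fold lower number from compound 1 to compound 4 (1.20 log units; beyond the scatter) and matches what compound 2 already suggested for the enone chain, though this step rests on a limit for compound 1: the limit of > 10000 nM in this assay, at which 1 of the 4 values shown sits.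

Open, from the compounds shown here alone, is whether other groups on the phenyl ketone, such as a hydroxyl or a dimethylamino group, would raise the number as the amino group of compound 3 does. Also open, going by these compounds, is whether a thiophene or pyridine ring, or a simple methyl group, on the carbonyl carbon would stay within the scatter of compounds 2 and 4.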